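Swapping the aryl group on the shared core

A few compounds are considered here, and "the series" means these few. Any claim that something is new, unique, unknown or untested is made for them only; others in the source may bear on it.

Measured so far:
compound 1, `COc1cc(/C=C/C(=O)C2=C(/C=C/c3ccc(O)c(OC)c3)NC(=S)NC2c2ccc(C)cc2)ccc1O`: 19.9%
compound 2, `COc1cc(/C=C/C(=O)C2=C(/C=C/c3ccc(O)c(OC)c3)NC(=S)NC2c2ccc(N(C)C)cc2)ccc1O`: 59%

In a functional assay, with a stated time of 20 min, tested at 10 uM (on this read-out lower numbers stand for a weaker effect and higher numbers for a stronger effect at the one concentration tested), compound 2 gives 59%, the higher of the two numbers; the other, compound 1, gives 19.9%. For the measured compounds named here, the one step between them is a number 39.1 percentage points higher from compound 1 to compound 2 (beyond the scatter), a change that lies beyond the scatter.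

Compound 3, `COc1cc(/C=C/C(=O)C2=C(/C=C/c3ccc(O)c(OC)c3)NC(=S)NC2c2ccccc2Cl)ccc1O`, has not yet been tested in this assay. It differs from compound 2 in one place: 2-chlorophenyl in place of 4-(dimethylamino)phenyl on a saturated ring carbon. Going by the values given here, the only step available that bears on this change is a number 39.1 percentage points higher from compound 1 to compound 2 (beyond the scatter), which shows that removing the dimethylamino group went with a large fall. Compound 3 also lacks that group, and the 2-chlorophenyl that enters has no hydrogen-bond acceptor, much like the methyl-bearing ring of compound 1. A fall of a similar size is therefore expected, though the chlorine carries its own uncertainty. For compound 3 in this assay the expected value is 25%, with a range from 5% to 50%. This estimate means a step of a number 34 percentage points lower from compound 2 to compound 3 (beyond the scatter) that is expected to be beyond the scatter.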

Compound 3, a percentage reported as activity, at one concentration (the size of the read-out at that concentration, not a potency): 21.2%
Estimate against measurement, compound 3: 3.8 percentage points above; the range from low to high includes it.
By their numbers in this assay, from the lowest: compounds 1 and 3 (each within the scatter of the next); then compound 2.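

In this assay, the new result shows that the large gap seen earlier at this saturated ring carbon does not depend on 4-methylphenyl as the partner: a number 37.8 percentage points lower from compound 2 to compound 3 (beyond the scatter) is a second large step, this time against a ring with a different substituent in a different place. Meanwhile, a number 1.3 percentage points higher from compound 1 to compound 3 (within the scatter) is a step within the scatter, so 4-methylphenyl and 2-chlorophenyl cannot be told apart on this read-out, even though the two rings differ both in the group they carry and in where it sits. Among these three compounds, only the one with 4-(dimethylamino)phenyl stands apart, but nothing measured here explains why. The compounds shown leave open whether a plain amino group, a methoxy group or a morpholine ring on the phenyl ring would give a number like that of compound 2 or one like those of the other two. They also leave open whether a dimethylamino group placed elsewhere on the phenyl ring would give the same number as in compound 2.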